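A few compounds are considered here, and "the series" means these few. Any claim that something is new, unique, unknown or untested is made for them only; others in the source may bear on it.

Compound 3 `O=C1CC(=C(c2ccccc2)c2ccccc2)C(=O)N1CCN1CCN(c2ccccc2)CC1` is measured in an assay on membranes from Cerebral cortex for binding affinity to Adrenergic receptor alpha-1 (Rattus norvegicus), read by radioligand binding (a lower number here means a stronger inhibitor, a higher number a weaker inhibitor), where compound 3 gives 214 nM. Two close relatives carry a shorter link between the shared core and the piperazine: compound 1 `O=C1CC(=C(c2ccccc2)c2ccccc2)C(=O)N1CN1CCN(c2cccc(Cl)c2)CC1` gives 392 nM, a number within the scatter of compound 3, and compound 2 `O=C1CC(=C(c2ccccc2)c2ccccc2)C(=O)N1CN1CCN(c2ccc(F)cc2)CC1` gives 746 nM, which lies beyond the scatter of compound 3. Compound 4 `O=C1CC(=C(c2ccccc2)c2ccccc2)C(=O)N1CCN1CCN(c2cccc(C(F)(F)F)c2)CC1` differs from compound 3 in one place: trifluoromethyl in place of hydrogen on an aromatic carbon. Among the measured compounds shown here, the only measured step that touches the same region is the change of the aromatic substituent on the piperazine nitrogen, a 1.9-fold higher number from compound 1 to compound 2 (0.28 log units; within the scatter), and it stayed within the scatter. For the measured compounds named here, that step exchanged one halogen pattern for another rather than adding a group to an unsubstituted ring, so it bears on compound 4 only loosely; no measured pair shows a trifluoromethyl group entering or leaving. On that basis the move from compound 3 to compound 4 is expected to be modest, with no clear direction beyond the scatter, and the estimated step is a 1.1-fold lower number from compound 3 to compound 4 (0.05 log units; within the scatter). Compound 4 is therefore expected to give about 190 nM in this assay, with a range from 60 nM to 600 nM.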

Compound 4, inhibition constant: > 1000 nM
Compound 4: a limit, no number; the forecaster's own chance of this, stated with the estimate: 2%; middle value at least 5.2-fold (0.72 log units) from the limit.
By their numbers in this assay, from the lowest: compounds 3, 1 and 2 (each within the scatter of the next, the first and the last beyond it). At a limit, above all of these: compound 4.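

In this assay, the change from phenyl to 3-(trifluoromethyl)phenyl gives an at least 4.6-fold higher number from compound 3 to compound 4 (0.66 log units; beyond the scatter), which shows that this aromatic carbon is not indifferent to what it carries. Among the compounds shown here, the one earlier step on this aryl group, a 1.9-fold higher number from compound 1 to compound 2 (0.28 log units; within the scatter), stayed within the scatter and involved no group entering an unsubstituted ring, so it could not show this; here, adding trifluoromethyl to the plain phenyl of compound 3 produces a step beyond the scatter. The reading for compound 4 is a limit and not a number, so the step fixes only a lower bound on its size: the limit of > 1000 nM in this assay, at which 1 of the 4 values shown sits.

The compounds shown leave open whether a methyl group, a chlorine or a methoxy group at the same place would move the number as trifluoromethyl does, or whether this step belongs to trifluoromethyl alone. They also leave open whether trifluoromethyl would have a step of similar size on the shorter link carried by compound 1 and compound 2, and what number compound 4 would give beyond its limit.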